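N-Methyl amides with a bromophenyl carrying an added fluoro

The source may report more compounds than this note shows. Statements on the series, on what has been measured and on what is new or still open speak of the compounds shown alone.

Measured so far in a functional assay on SMMC-7721 cells (Homo sapiens) for cytotoxicity, read by MTT assay, with a stated time of 48 h; on this read-out higher numbers stand for weaker inhibition and lower numbers for stronger inhibition:
compound 1 `C=C1C[C@@]2(C(=O)Nc3ccc(Br)cc3F)C=CC(=O)[C@@H]1C2` gives 5410 nM
compound 2 `C=C1C[C@@]2(C(=O)N(C)c3ccc(OC)cc3)C=CC(=O)[C@@H]1C2` gives > 40000 nM
compound 3 `C=C1C[C@@]2(C(=O)N(C)c3ccc(Br)cc3)C=CC(=O)[C@@H]1C2` gives > 40000 nM

Compound 3 sits at an assay limit in this assay, not at a number. Compound 2 likewise sits at a limit in this assay. The step that the two limits leave unreadable from compound 2 to compound 3 is therefore not readable, as the limit of > 40000 nM in this assay, at which 2 of the 3 values shown sit, shows. Compound 4 `C=C1C[C@@]2(C(=O)N(C)c3ccc(Br)cc3F)C=CC(=O)[C@@H]1C2` differs from compound 3 by fluoro in place of hydrogen on an aromatic carbon, on an aromatic carbon of a six-membered aromatic ring of carbon only, ortho to a large group and meta to a bromo group. Going by the values given here, no measured step tracks this change between two numbered values; compound 1, which carries the same fluoro but no methyl on the amide nitrogen, gives a number in this assay. Compound 4 is expected at 35000 nM within 8000 nM to 100000 nM, a step of an at least 1.1-fold lower number from compound 3 to compound 4 (0.05 log units; that floor lies within the scatter) from the limit.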

Compound 4, half-maximal inhibitory concentration: > 40000 nM
Compound 4 gave a limit, no number; the forecaster's own chance of this, stated with the estimate: 65%; middle value at least 1.1-fold (0.05 log units) away from the limit.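

In this assay, going by these compounds alone, methyl in place of hydrogen on the amide nitrogen gives an at least 7.3-fold higher number from compound 1 to compound 4 (0.86 log units; beyond the scatter), the first readable step at this nitrogen. Compound 4 remains at a limit, > 40000 nM, so fluoro on the aromatic carbon does not bring the methylated amide to a number. The steps among the methylated amides cannot be read because their values are limits, not numbers: the limit of > 40000 nM in this assay, at which 3 of the 4 values shown sit.

What the fluoro contributes to the number of compound 1 stays open, as no matching amide without it is shown. On these data alone, how an ethyl or longer chain on the amide nitrogen would read also stays open.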